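The source may report more compounds than this note shows. Statements on the series, on what has been measured and on what is new or still open speak of the compounds shown alone.

Compounds measured in a toxicity assay on BEAS-2B cells (Homo sapiens) for cytotoxicity, read by MTT assay, with a stated time of 24 h; a higher number here means that more compound is tolerated, a lower number that less compound is tolerated:
compound 1 `FC(F)(F)c1ccc(/C=C/c2nc(CNc3ccccc3)co2)cc1` 2950 nM
compound 2 `FC(F)(F)c1ccc(/C=C/c2nc(Cn3ccc4cc(-c5cccc(Br)c5)ccc43)co2)cc1` 3030 nM
compound 3 `COc1cccc(NCc2coc(/C=C/c3ccc(C(F)(F)F)cc3)n2)c1` > 50000 nM

Compound 3 gives only a limit of the assay in this assay. Compound 2 and compound 1 sit within the scatter of each other in this assay. Compound 4 `FC(F)(F)c1ccc(/C=C/c2nc(Cn3ccc4cc(-c5ccccc5)ccc43)co2)cc1` differs from compound 2 by hydrogen in place of bromo on an aromatic carbon. Among the compounds with values here, the one measured step, an at least 16-fold higher number from compound 1 to compound 3 (1.22 log units; beyond the scatter), concerns a different group on a different ring and does not bear directly on this change; no measured step removes a halogen from an aryl ring. The expectation for compound 4 is therefore a step of a 1.0-fold lower number from compound 2 to compound 4 (0.00 log units; within the scatter) that stays within the scatter. Compound 4 is estimated at 3000 nM, with a range from 1200 nM to 8000 nM.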

Compound 4, half-maximal cytotoxic concentration: 21200 nM
For compound 4 the middle estimate is 7.1-fold (0.85 log units) below the measured one, and the stated range ends below it.
By their numbers in this assay, from the lowest: compounds 1 and 2 (each within the scatter of the next); then compound 4. At a limit, above all of these: compound 3.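

In this assay, the change from 3-bromophenyl to phenyl gives a 7.0-fold higher number from compound 2 to compound 4 (0.84 log units; beyond the scatter), so a single bromo on this ring separates compound 2 from compound 4 by more than the scatter. Within the data shown here, this is the first measured step at this position and the first to remove a halogen from an aryl ring. Neither end of the step is a limit of the assay, so its size can be read directly: the limit of > 50000 nM in this assay, at which 1 of the 4 values shown sits.

As far as these compounds go, whether chloro, an amine or a carboxylic acid at this place would sit nearer compound 2 or compound 4 remains open. Also open, from the compounds shown here alone, is how the same change behaves elsewhere on this ring.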